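The source may report more compounds than this note shows. Statements on the series, on what has been measured and on what is new or still open speak of the compounds shown alone.

Compound 1, `CN1CCN(Cc2nnc(-c3cc(S(N)(=O)=O)c(SCc4ccccc4)cc3Cl)o2)CC1`: 75000 nM
Compound 2, `[N-]=[N+]=NCc1nnc(-c2cc(S(N)(=O)=O)c(SCc3ccccc3)cc2Cl)o1`: 115000 nM

Of the compounds shown here, two have been measured in a functional assay on HeLa cells (Homo sapiens) for cytotoxicity, read by MTT assay, with a stated time of 72 h; on this read-out lower numbers stand for stronger inhibition and higher numbers for weaker inhibition. Compound 2 gives 115000 nM and compound 1 gives 75000 nM; the step of a 1.5-fold higher number from compound 1 to compound 2 (0.19 log units; within the scatter) lies within the scatter, so compound 2 stands level with compound 1 on the numbers shown. Compound 3, `CCOC(=O)c1cn(Cc2nnc(-c3cc(S(N)(=O)=O)c(SCc4ccccc4)cc3Cl)o2)nn1`, has not yet been measured. It differs from compound 2 by 4-(ethoxycarbonyl)-1H-1,2,3-triazol-1-yl in place of azido on a saturated chain carbon bound to an aromatic carbon. Among the compounds with values here, the only measured step at this place is a 1.5-fold higher number from compound 1 to compound 2 (0.19 log units; within the scatter), where exchanging one group for another on the same chain carbon left the number within the scatter. Within the data shown here, no measured compound carries the 4-(ethoxycarbonyl)-1H-1,2,3-triazol-1-yl group, so the expectation rests on that single step. Compound 3 is expected to show a 1.2-fold lower number from compound 2 to compound 3 (0.06 log units; within the scatter), that is no step beyond the scatter. The estimate for compound 3 in this assay is 100000 nM, with a range from 40000 nM to 300000 nM.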

Compound 3, half-maximal inhibitory concentration: 122000 nM
Compound 3: middle estimate off by 1.2-fold (0.09 log units), on the low side; the measured number falls inside the stated range.
By their numbers in this assay, from the lowest: compounds 1, 2 and 3 (each within the scatter of the next).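

In this assay, 4-(ethoxycarbonyl)-1H-1,2,3-triazol-1-yl in place of azido on a saturated chain carbon bound to an aromatic carbon gives only (a 1.1-fold higher number from compound 2 to compound 3 (0.03 log units; within the scatter)), and the same group in place of 4-methylpiperazin-1-yl gives (a 1.6-fold higher number from compound 1 to compound 3 (0.21 log units; within the scatter)). Within the data shown here, this position has now carried three different groups, including one with a five-membered aromatic ring and 10 heavy atoms against the 3 of azido, and no step among the three compounds leaves the scatter. Nothing at hand gives a reason for this result.

As far as these compounds go, it remains open whether a carboxylic acid in place of the ethoxycarbonyl group, or a primary amine on the same chain carbon, would move the number beyond the scatter. Also open, from the compounds shown here alone, is what a change elsewhere on the shared core would do, such as an amine in place of the chlorine.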